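This account rests on a few compounds, and the source may have more. Where it says the series, first, only, none or still open, it means among the compounds named here.

Measured compounds:
- compound 1 `CCCCC1=NC2(CCCCC2)C(=O)N1Cc1ccc(-c2ccccc2C(=O)O)cc1`: 860 nM
- compound 2 `CCCCC1NC(=O)C2(CCCC2)N1Cc1ccc(-c2ccccc2C(=O)O)cc1`: 24200 nM
- compound 3 `CCCC[C@@H]1N(Cc2ccc(-c3ccccc3-c3nnn[nH]3)cc2)C(=O)[C@@H]2CCCN12`: "not active" (no number reported)

In a functional assay on CHO-K1 cells for agonist activity at leukotriene B4 receptor 2 (Homo sapiens), read by HTRF and inositol phosphate accumulation, with a stated time of 90 min (a higher number here means that more compound is needed for the effect, a lower number that less compound is needed), compound 1 gives 860 nM, and compound 2 gives 24200 nM in the same assay. For the measured compounds named here, no step between these two is worked out here; their two values simply stand side by side. Compound 3 is recorded in this assay as "not active" (no number reported), so no number is available for it and nothing about its distance from compound 1 or compound 2 can be stated.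

Compound 4 `CCCC[C@H]1N(Cc2ccc(-c3ccccc3-c3nnn[nH]3)cc2)C(=O)[C@H]2CCCN21` is the unmeasured partner of compound 3. The difference is the two compounds have the same atoms and bonds and differ only in configuration as drawn: 2 of 2 stereo elements differ (all stereocentres are inverted: mirror images); a stereocentre at a saturated ring carbon is drawn S in compound 3 and R in compound 4; a stereocentre at a saturated ring carbon is drawn S in compound 3 and R in compound 4. Nothing in the series shows how a pair of mirror images behaves in this assay, so no step size can be taken from the data. As far as these compounds go, with compound 3 reported as inactive, the expectation rests only on the possibility that the mirror image carries whatever activity this pair has; the size of any such step in this assay is unknown, and the direction can only be toward measurable activity, since the starting point has no number.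

Compound 4 is therefore estimated at 5000 nM in this assay, within a range from 500 nM to 30000 nM, with a substantial chance that it too is reported only as inactive.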

Compound 4, half-maximal effective concentration: 7500 nM
Compound 4: middle estimate off by 1.5-fold (0.18 log units), on the low side; low and high end bracket the measured number.
By their numbers in this assay, from the lowest: compound 1; then compound 4; then compound 2.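

In this assay compound 4 gives 7500 nM, whereas compound 3 is recorded as "not active" with no number, so no step can be read between these two mirror images. The compounds shown leave open how large the separation between compound 3 and compound 4 is in this assay.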